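This account rests on a few compounds, and the source may have more. Where it says the series, first, only, none or still open, it means among the compounds named here.

Of the compounds shown here, two have so far been tested in a functional assay on the whole organism (Tail, strain ICR) with Mus musculus as the target, in the tail flick test, with a stated time of 90 min, at a dose of 25 umol/kg by the oral route; on this read-out higher numbers stand for a stronger effect at the one dose given and lower numbers for a weaker effect. Compound 1 `O=C(O)CC[C@H](NC(=O)CN(c1nc(Cl)nc2[nH]cnc12)C1CC1)C(=O)O` gives 44.7%, and compound 2 `C[C@H](NC(=O)CN(c1ncnc2c1ncn2C1CCCCO1)C1CC1)C(=O)OCc1ccccc1` gives 32.1%. Within the data shown here, compound 1 therefore stands highest of the two numbers known, with compound 2 lying lower by a gap that goes beyond the usual scatter of the measurement. Compound 3 `CSCC[C@H](NC(=O)CN(c1nc(Cl)nc2[nH]cnc12)C1CC1)C(=O)O` has not yet been measured. It differs from compound 1 in a single place: methylsulfanyl in place of carboxy on a saturated chain carbon, three bonds along the chain from an amide-type nitrogen and a carbonyl carbon. Among the measured compounds shown here, no measured pair shows what this exchange does on its own, since compound 2 differs from compound 1 in several places at once, so the expectation must be wide. The step from compound 1 to compound 3 is estimated at a number 4.7 percentage points lower from compound 1 to compound 3 (within the scatter), a change no larger than the scatter. In this assay compound 3 is expected to give about 40%, with a range from 20% to 60%.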

Compound 3, a percentage reported as activity, at one dose (the size of the read-out at that dose, not a potency): 14%
Beside the measured number, compound 3's estimate is 26 percentage points above it; measured number below the stated range.
By their numbers in this assay, from the lowest: compound 3; then compound 2; then compound 1.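

Among these compounds, exchanging carboxy for methylsulfanyl, on a saturated chain carbon, three bonds along the chain from an amide-type nitrogen and a carbonyl carbon, is the first change in a single place that can be read in this assay, and the step is a number 30.7 percentage points lower from compound 1 to compound 3 (beyond the scatter) for this one exchange. The earlier compounds shown here could not show this, as they differ in several places at once; this pair shows that the effect at the one dose given depends on what stands at this place, with the rest of the molecule unchanged. Nothing measured here bears on what lies behind this drop.

Going by these compounds, whether an amine, a hydroxyl or a shorter chain ending in a carboxylic acid would keep the effect of compound 1 stays open. So does whether the same exchange would act alike on the core of compound 2.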